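Swapping the benzyl substituent in an alpha-1B antagonist series

The source may report more compounds than this note shows. Statements on the series, on what has been measured and on what is new or still open speak of the compounds shown alone.

Measured so far:
Compound 1, `COc1cccc(OC)c1OCCNCCOc1ccccc1OCc1cccc(C)c1`, gives 8.2.
Compound 2, `COc1cccc(OC)c1OCCNCCOc1ccccc1OCc1cccc([N+](=O)[O-])c1`, gives 8.74.

In a functional assay on spleen for antagonist activity at Alpha-1B adrenergic receptor (Rattus norvegicus) (a lower number here means a less potent compound, a higher number a more potent compound, by a factor of ten per unit of this negative logarithm), compound 2 holds the higher of the two numbers, and compound 1 sits beyond the scatter below it. For the measured compounds named here, the one step measured so far, a number 0.54 log units higher from compound 1 to compound 2 (beyond the scatter), is the only guide available. Compound 3, `CCOc1ccc(COc2ccccc2OCCNCCOc2c(OC)cccc2OC)cc1`, has not yet been tested; its change from compound 2 is 4-ethoxyphenyl in place of 3-nitrophenyl on a saturated chain carbon bound to an oxygen on an aromatic ring. Going by the values given here, no measured step covers an ethoxy group or this ring position, so the step from compound 1 to compound 2 bears on it only in the sense that removing the nitro group takes away the feature that went with the higher number. A value near that of compound 1 therefore seems the most reasonable expectation, with wide uncertainty. Compound 3 is estimated at 8.3, within 7.6 to 9, an expected step of a number 0.44 log units lower from compound 2 to compound 3 (beyond the scatter).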

Compound 3, negative logarithm of the antagonist equilibrium constant: 8.23
Beside the measured number, compound 3's estimate is 0.07 log units above it; measured number inside the range.
By their numbers in this assay, from the lowest: compounds 1 and 3 (each within the scatter of the next); then compound 2.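

In this assay, replacing 3-nitrophenyl with 4-ethoxyphenyl gives a number 0.51 log units lower from compound 2 to compound 3 (beyond the scatter), so the higher number of compound 2 does not carry over to this other substituted ring. Replacing 3-methylphenyl with 4-ethoxyphenyl gives a number 0.03 log units higher from compound 1 to compound 3 (within the scatter), so these two groups cannot be told apart here, and among the three compounds only the 3-nitrophenyl group stands apart. No measurement here explains why the numbers fall this way.

The step from compound 2 to compound 3 changes both the substituent and its place on the ring, so the two changes cannot be separated; 4-nitrophenyl or 3-ethoxyphenyl would pull them apart. As far as these compounds go, it also remains open how a plain phenyl ring, or one carrying an amine or a carboxylic acid, would compare at this position.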